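Chloro to cyano on a shared core: expected cell effect

The source may report more compounds than this note shows. Statements on the series, on what has been measured and on what is new or still open speak of the compounds shown alone.

Measured compounds:
compound 1, `O=C(N/N=C/c1ccccc1Cl)c1cnccn1`: 66%
compound 2, `O=C(N/N=C/c1cccc(Cl)c1)c1cnccn1`: 100%
compound 3, `CCOc1ccc(/C=N/NC(=O)c2cnccn2)cc1`: 98%

In an ADME assay on J774 cells (Mus musculus) for cytotoxicity, read by MTT assay, with a stated time of 48 h, tested at 100 ug/mL (a higher number here means a weaker effect of the compound at the concentration tested, a lower number a stronger effect), compound 2 gives 100%, the highest of the three numbers. Compound 3 sits closest, and the two values lie within the usual scatter of each other, so they cannot be told apart. Compound 1 lies furthest away, beyond the scatter, with the stronger effect of the three. Among the compounds with values here, no two measured compounds differ in only one place, so no single step has been measured. Compound 4, `N#Cc1cccc(/C=N/NC(=O)c2cnccn2)c1`, differs from compound 2 in one place: cyano in place of chloro on an aromatic carbon. With nothing to go on but the structural change, the step from compound 2 to compound 4 in this assay is expected to be small, in no particular direction, and not beyond the scatter. Compound 4 is therefore estimated at 94%, within 70% to 105%, the expected step being a number 6 percentage points lower from compound 2 to compound 4 (within the scatter).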

Compound 4, a percentage reported as activity, at one concentration (the size of the read-out at that concentration, not a potency): 100%
Compound 4: middle estimate off by 6 percentage points, on the low side; the range from low to high includes it.
By their numbers in this assay, from the lowest: compound 1; then compounds 3, 2 and 4 (each within the scatter of the next).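

In this assay, within the data shown here, the swap of cyano in place of chloro on an aromatic carbon, meta to a large group, shows no change at the digits printed from compound 2 to compound 4 (within the scatter) and is the first single change that can be read on the shared core. At this position, the extra heavy atom and the hydrogen-bond acceptor that cyano brings leave the read-out unmoved. Nothing measured here offers an explanation for this result.

As far as these compounds go, whether an amine or a carboxylic acid at this position would also leave the read-out unmoved remains open. So does whether cyano in place of chloro would do the same on compound 1.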